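Removing the bromo group from the chalcone of compound 1

The compounds below may be only part of what the source reports. "The series", "measured", "known", "first", "only" and "open" are said of these compounds alone.

Compound 1 `COc1cc(/C=C/C(=O)c2ccc(N)c(-c3ccc(F)cc3)c2)cc(Br)c1O` is the only entry here that comes with a number. In a functional assay on HepG2 cells (Homo sapiens) for cytotoxicity, read by sulforhodamine B assay, with a stated time of 48 h (on this read-out lower numbers stand for stronger inhibition and higher numbers for weaker inhibition), compound 1 gives 4730 nM. Compound 2 `COc1ccc(/C=C/C(=O)c2cccc(Br)c2)cc1` has no result in this assay; for compound 2 the entry reads "not determined" (no result reported). Compound 1 therefore stands alone on the numbers shown, with nothing measured to rank it against.

Compound 3 `COc1cc(/C=C/C(=O)c2ccc(N)c(-c3ccc(F)cc3)c2)ccc1O` differs from compound 1 by hydrogen in place of bromo on an aromatic carbon. The change is small in bulk: one bromine atom leaves and only a hydrogen enters, on an aromatic carbon ortho to a hydroxy group and meta to a methoxy group, while the rest of the structure, including the amine and the fluorophenyl group, is unchanged. Within the data shown here, no step between measured compounds exists to calibrate such a change in this assay.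

Expectation: losing a single heavy atom is expected to shift this assay only modestly, at the edge of the usual scatter and, if anything, toward weaker inhibition. The step expected is a 1.6-fold higher number from compound 1 to compound 3 (0.20 log units; within the scatter). For compound 3 the estimate in this assay is 7500 nM, with a range from 2500 nM to 22000 nM.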

Compound 3, half-maximal inhibitory concentration: 4300 nM
Estimate against measurement, compound 3: 1.7-fold (0.24 log units) above; measured number inside the range.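

In this assay, among these compounds, hydrogen in place of bromo on the aromatic carbon ortho to a hydroxy group gives a 1.1-fold lower number from compound 1 to compound 3 (0.04 log units; within the scatter), the first step that can be read. At this position, and with the amine and the fluorophenyl group unchanged, the bromo group can therefore be exchanged for hydrogen without a difference that stands out from repeated measurements, so the two compounds count as equal on this read-out. No measurement of any property accompanies the step, so the result stands as an observation without an explanation.

Among the compounds shown here, what remains open is whether this carbon tolerates substituents in general or only this one exchange, since a single step spans only bromo and hydrogen and says nothing about how a chlorine atom, a methoxy group, an amine or a carboxylic acid would read here. Also open, as far as these compounds go, is whether the same exchange would stay equally flat in a compound that differs from compound 1 elsewhere on the shared core.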